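The source may hold more compounds than are shown below. What is called first, only, known or untested is meant among the compounds shown, and "the series" means these compounds.

Measured compounds in a functional assay on HT-1080 cells (Homo sapiens) for inhibition, read by MTT assay, with a stated time of 48 h; on this read-out lower numbers stand for stronger inhibition and higher numbers for weaker inhibition:
compound 1, `COc1cc(-c2nc3cc(/C=C4\SC(=O)NC4=O)ccc3[nH]2)cc(OC)c1OC`, 3120 nM
compound 2, `COc1cc(-c2nc3cc(/C=C4\SC(=O)N(CC(=O)N5CCCCC5)C4=O)ccc3[nH]2)cc(OC)c1OC`, 3650 nM

Among these two numbers compound 2 stands highest, its nearest neighbour being compound 1, yet the step of a 1.2-fold higher number from compound 1 to compound 2 (0.07 log units; within the scatter) lies within the scatter, so the two values cannot be ordered. Compound 3, `COc1cc(-c2nc3cc(/C=C4\SC(=O)N(CC(=O)N5CCCC5)C4=O)ccc3[nH]2)cc(OC)c1OC`, differs from compound 2 by pyrrolidin-1-yl in place of piperidin-1-yl on a carbonyl carbon. Within the data shown here, no measured pair shows this exchange of a six-membered for a five-membered ring on the carbonyl carbon; the only step available, a 1.2-fold higher number from compound 1 to compound 2 (0.07 log units; within the scatter), concerns the whole ((piperidin-1-yl)carbonyl)methyl group on the amide-type nitrogen and cannot speak to the ring size within it. Among the measured compounds shown here, since the one change in that region of compound 2 left the number unmoved, a smaller ring is expected to do little. Compound 3 is therefore estimated at 3500 nM, within 1500 nM to 8000 nM, and the expected step from compound 2 to compound 3 is a 1.0-fold lower number from compound 2 to compound 3 (0.02 log units; within the scatter), none beyond the scatter.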

Compound 3, half-maximal inhibitory concentration: 2470 nM
The estimate for compound 3 lay 1.4-fold (0.15 log units) above the measured number; low and high end bracket the measured number.
By their numbers in this assay, from the lowest: compounds 3, 1 and 2 (each within the scatter of the next).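

In this assay, the ring size on the carbonyl carbon can now be judged directly: pyrrolidin-1-yl in place of piperidin-1-yl gives a 1.5-fold lower number from compound 2 to compound 3 (0.17 log units; within the scatter) and thus no readable effect. The second substituent on the amide-type nitrogen behaves like the first, as ((pyrrolidin-1-yl)carbonyl)methyl in place of hydrogen gives a 1.3-fold lower number from compound 1 to compound 3 (0.10 log units; within the scatter) and does not separate from the unsubstituted compound. No supporting evidence bears on these results.

The compounds shown leave open whether a ring with a second hetero atom, such as morpholin-4-yl, or an open-chain diethylamino group on the carbonyl carbon would move the number beyond the scatter. They also leave open whether a carboxylic acid or a longer chain on the amide-type nitrogen would do so.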